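Swapping bromo for trifluoromethyl on compound 1

The source may hold more compounds than are shown below. What is called first, only, known or untested is meant among the compounds shown, and "the series" means these compounds.

Measured compounds:
compound 1 `O=C1C(Nc2ccc(Br)cc2)=CC(=O)c2c1nc1n2[C@H]2OC[C@@H](O)[C@H]2OC1`: 5220 nM
compound 2 `O=C1C(N2CCCC2)=CC(=O)c2c1nc1n2[C@H]2OC[C@@H](O)[C@H]2OC1`: > 16000 nM
compound 3 `O=C1C(N2CCCCC2)=CC(=O)c2c1nc1n2[C@H]2OC[C@@H](O)[C@H]2OC1`: > 16000 nM

Among the measured compounds shown here, in a functional assay on HeLa cells (Homo sapiens) for inhibition, read by sulforhodamine B assay (a lower number here means a stronger inhibitor, a higher number a weaker inhibitor), compound 1 gives 5220 nM, the only true number in this set. Compound 2 reads > 16000 nM, which is a limit of the assay. Compound 3 reads > 16000 nM, also a limit.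

Compound 4 `O=C1C(Nc2ccc(C(F)(F)F)cc2)=CC(=O)c2c1nc1n2[C@H]2OC[C@@H](O)[C@H]2OC1` differs from compound 1 by trifluoromethyl in place of bromo on an aromatic carbon.

For the measured compounds named here, two measured steps bear on this only indirectly: an at least 3.0-fold higher number from compound 1 to compound 2 (0.48 log units; beyond the scatter) and an at least 3.0-fold higher number from compound 1 to compound 3 (0.48 log units; beyond the scatter). Both remove the whole (4-bromophenyl)amino group, which compound 4 largely keeps, and neither tests the bromo alone. No size beyond the scatter is therefore expected in this assay.

The expected step is a 1.0-fold lower number from compound 1 to compound 4 (0.02 log units; within the scatter). For compound 4 the estimated value is 5000 nM, with an expected range of 2000 nM to 13000 nM.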

Compound 4, half-maximal inhibitory concentration: 8920 nM
The estimate for compound 4 lay 1.8-fold (0.25 log units) below the measured number; the measured number falls inside the stated range.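

In this assay, the change from 4-bromophenyl to 4-(trifluoromethyl)phenyl gives a 1.7-fold higher number from compound 1 to compound 4 (0.23 log units; within the scatter). The earlier steps shown here replaced the whole (4-bromophenyl)amino group, whereas this one alters only the group on the aromatic ring and keeps the amino link. At this position, trifluoromethyl can therefore stand in for bromo without a change beyond the scatter.

As far as these compounds go, whether a hydrogen, a methoxy group or a carboxylic acid at this place would shift the number remains open. Few readable numbers are available to settle this: the limit of > 16000 nM in this assay, at which 2 of the 4 values shown sit.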